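Benzyl Sulfanyl Enones Against DU-145 Growth

This account rests on a few compounds, and the source may have more. Where it says the series, first, only, none or still open, it means among the compounds named here.

The study concerns three measured enones and one yet to be tested. Compound 1 `O=C(O)c1ccc(C(=O)/C(=C\c2ccc(Br)c([N+](=O)[O-])c2)SCc2ccc(Cl)cc2Cl)cc1` carries a 2,4-dichlorobenzyl sulfanyl group on the enone; in a functional assay on DU-145 cells (Homo sapiens) for inhibition, read by trypan blue exclusion, with a stated time of 96 h (a lower number here means a stronger inhibitor of growth, a higher number a weaker inhibitor of growth), compound 1 gives 1000 nM. Compound 3 `O=C(O)c1ccc(C(=O)/C(=C\c2ccc(Br)c([N+](=O)[O-])c2)SCc2ccc(F)cc2)cc1` differs from it by 4-fluorophenyl in place of 2,4-dichlorophenyl on a saturated chain carbon bound to a sulfur, and in this assay compound 3 gives 1000 nM. The step of no change at the digits printed from compound 1 to compound 3 (within the scatter) therefore moves nothing that the assay can resolve.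

Compound 2 `COc1cc(OC)c(/C=C(/SCc2ccc(Cl)cc2Cl)C(=O)c2ccc(Cl)cc2)c(OC)c1` is built on a different core; the difference between the cores of compound 1 and compound 2 is not broken down here. In this assay compound 2 gives 1000 nM, level with compound 1 and compound 3.

Compound 4 `COc1cc(OC)c(/C=C(/SCc2ccc(F)cc2)C(=O)c2ccc(Cl)cc2)c(OC)c1` has not been measured. It stands to compound 2 exactly as compound 3 stands to compound 1: the change is 4-fluorophenyl in place of 2,4-dichlorophenyl on a saturated chain carbon bound to a sulfur, made at the same place, so it is the same change seen once already. Because the earlier step of no change at the digits printed from compound 1 to compound 3 (within the scatter) stayed within the scatter, and because compound 2 sits at 1000 nM, the author expects the step of no change at the digits printed from compound 2 to compound 4 (within the scatter) to be of like size, that is, essentially flat. On that basis compound 4 is estimated in this assay to give 1000 nM, with the expected range running from 500 nM to 2000 nM.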

Compound 4, concentration for 50% growth inhibition: 10000 nM
For compound 4 the middle estimate is 10-fold (1.00 log units) below the measured one; the measured number lies above the stated range.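

In this assay, exchanging 2,4-dichlorobenzyl for 4-fluorobenzyl on the sulfur of the core of compound 2 gives a 10-fold higher number from compound 2 to compound 4 (1.00 log units; beyond the scatter). The exchange therefore does not carry over at a fixed size from one core to the other in this series, and a flat result on the core of compound 1 gave no safe guide to its result on the core of compound 2: the same change on two cores in this assay, no change at the digits printed (within the scatter) from compound 1 to compound 3 and a 10-fold higher number (1.00 log units; beyond the scatter) from compound 2 to compound 4, 10-fold (1.00 log units) apart, beyond the scatter of two such steps

Within the data shown here, this shows that the outcome of the change depends on the core, but it rests on only one matched pair per core, and it does not show which feature of the two cores is responsible, why the steps differ, or how the change would behave on any third core.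

The compounds shown leave open whether the step from compound 2 to compound 4 follows from losing the chlorine atoms or from gaining the fluorine atom, a question that a plain benzyl group or a 4-chlorobenzyl group on the sulfur of the same core could help to separate. They also leave open which of the several differences between the two cores sets the size of the step, a question that would need intermediate cores that differ from one another in a single place.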